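Urea variation on the oxadiazole series: sulfamoylphenyl to chlorotrifluoromethylphenyl

The compounds below may be only part of what the source reports. "The series", "measured", "known", "first", "only" and "open" are said of these compounds alone.

Compound 1 `O=C(Nc1cccc(-c2nc(-c3ccc(NC(=O)c4cccnc4)cc3Cl)no2)c1)c1ccccc1` carries a benzamide and in a functional assay on MDA-MB-231 cells (Homo sapiens) for antiproliferative activity, read by MTT assay, with a stated time of 72 h (a lower number here means a stronger inhibitor, a higher number a weaker inhibitor), compound 1 gives 12800 nM. Compound 2 `O=C(Nc1ccc(S(=O)(=O)Nc2cccc(-c3nc(-c4ccc(NC(=O)c5cccnc5)cc4Cl)no3)c2)cc1)NC1CCCC1` in this assay reaches only the limit > 10000 nM. Compound 3 `NS(=O)(=O)c1ccc(NC(=O)Nc2cccc(-c3nc(-c4ccc(NC(=O)c5cccnc5)cc4Cl)no3)c2)cc1` likewise shows in this assay only the limit > 10000 nM, so compound 3 stands at the assay ceiling, not at a number. The step that the limit leaves unreadable from compound 1 to compound 3 is therefore of unreadable size, as the limit of > 10000 nM in this assay, at which 2 of the 3 values shown sit, notes for two of the three values.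

Compound 4 `O=C(Nc1cccc(-c2nc(-c3ccc(NC(=O)c4cccnc4)cc3Cl)no2)c1)Nc1ccc(Cl)c(C(F)(F)F)c1` differs from compound 3 by 4-chloro-3-(trifluoromethyl)phenyl in place of 4-sulfamoylphenyl on an amide-type nitrogen. No readable measured step bears on this change. The expected step of an at least 1.6-fold lower number from compound 3 to compound 4 (0.22 log units; that floor lies within the scatter) is accordingly uncertain and only loosely anchored. For compound 4 the estimated value is 6000 nM, expected to lie between 1500 nM and 25000 nM.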

Compound 4, half-maximal inhibitory concentration: 1900 nM
Beside the measured number, compound 4's estimate is 3.2-fold (0.50 log units) above it; measured number inside the range.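

In this assay, 4-chloro-3-(trifluoromethyl)phenyl in place of 4-sulfamoylphenyl on the amide-type nitrogen gives this position a readable direction, although the step remains a floor: an at least 5.2-fold lower number from compound 3 to compound 4 (0.72 log units; beyond the scatter). That floor rests on a limit for compound 3: the limit of > 10000 nM in this assay, at which 2 of the 4 values shown sit. The urea with the new group also separates from the benzamide, a 6.7-fold lower number from compound 1 to compound 4 (0.83 log units; beyond the scatter), a comparison that the limit for compound 3 could not provide.

It remains open whether the chlorine or the trifluoromethyl carries the step, since neither 4-chlorophenyl nor 3-(trifluoromethyl)phenyl alone stands among the compounds shown. On these data alone, how a carboxylic acid or an amine on this phenyl ring would read also remains open.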